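Same aryl swap on a second quinoline core

This account rests on a few compounds, and the source may have more. Where it says the series, first, only, none or still open, it means among the compounds named here.

Measured compounds:
compound 1, `COc1ccc2ncc(S(=O)(=O)c3ccc(C)cc3)c(N3CCC(C)CC3)c2c1`, 90% in an assay on isolated protein for displacement of a labelled ligand from metabotropic glutamate receptor 5 (Homo sapiens), with a stated time of 60 min, tested at 1 uM; on this read-out lower numbers stand for less inhibition and higher numbers for more inhibition at the one concentration tested (going by the name of the read-out)
compound 2, `COc1ccc2ncc(S(=O)(=O)c3cccc(Cl)c3)c(N3CCC(C)CC3)c2c1`, -3% in this assay
compound 3, `Cc1ccc(S(=O)(=O)c2cnc3ccc(C)cc3c2N2CCC(C)CC2)cc1`, 82% in this assay

The three compounds share a core that carries a sulfonyl-linked aryl ring and a 4-methylpiperidine. Compound 1 and compound 2 differ only in that ring: 3-chlorophenyl in place of 4-methylphenyl on a sulfonyl sulfur. In this assay this change gives a number 93 percentage points lower from compound 1 to compound 2 (beyond the scatter), a step far beyond the scatter.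

Compound 3 differs from compound 1 in the core itself: methyl in place of methoxy on an aromatic carbon. This change gives a number 8 percentage points lower from compound 1 to compound 3 (within the scatter), which lies within the scatter, so compound 1 and compound 3 are not separated by the measurement.

Compound 4, `Cc1ccc2ncc(S(=O)(=O)c3cccc(Cl)c3)c(N3CCC(C)CC3)c2c1`, has not been measured. It stands to compound 3 as compound 2 stands to compound 1: 3-chlorophenyl in place of 4-methylphenyl on a sulfonyl sulfur. The place of the change is the same in both pairs, on a sulfonyl sulfur whose other neighbour is an aromatic carbon, so this is the same change made on the second core. Because the step of a number 93 percentage points lower from compound 1 to compound 2 (beyond the scatter) was large and because compound 3 starts from 82%, close to compound 1, the step to compound 4 is expected to be of similar size, estimated as a number 87 percentage points lower from compound 3 to compound 4 (beyond the scatter). The estimate for compound 4 in this assay is -5%, with a likely range from -20% to 15%. This rests on one matched pair only, and nothing shows whether the methyl core changes the response to the aryl swap.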

Compound 4, a percentage reported as inhibition, at one concentration (the size of the read-out at that concentration, not a potency): 91%
Compound 4: the middle estimate sits 96 percentage points below what was measured; measured number outside the range, above it.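

In this assay, 3-chlorophenyl in place of 4-methylphenyl on a sulfonyl sulfur gives a number 9 percentage points higher from compound 3 to compound 4 (within the scatter), so the sharp drop seen on the core of compound 1 does not carry over to the core of compound 3: the same change on two cores in this assay, a number 93 percentage points lower (beyond the scatter) from compound 1 to compound 2 and a number 9 percentage points higher (within the scatter) from compound 3 to compound 4, 102 percentage points apart, beyond the scatter of two such steps

Read the other way, methyl in place of methoxy on an aromatic carbon gives a number 94 percentage points higher from compound 2 to compound 4 (beyond the scatter), so this change, too, has a different outcome depending on which aryl group the compound carries: the same change on two cores in this assay, a number 8 percentage points lower (within the scatter) from compound 1 to compound 3 and a number 94 percentage points higher (beyond the scatter) from compound 2 to compound 4, 102 percentage points apart, beyond the scatter of two such steps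

Within these four compounds, the result of the aryl swap therefore depends on the core, but the set does not show why the two cores differ, and compound 2 is the only one of the four with a low number, so the whole contrast rests on that single compound.

The compounds shown leave open what a plain phenyl on the sulfonyl sulfur would give on either core, and whether a morpholine in place of the 4-methylpiperidine would change the picture. They also leave open whether the contrast would hold in a read-out of potency rather than at the one concentration tested.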